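Cyclopropyl replaces the anilino aryl in the acrylamide series

The compounds below may be only part of what the source reports. "The series", "measured", "known", "first", "only" and "open" are said of these compounds alone.

Compound 3 `C=CC(=O)Nc1cc(Nc2ncc(Cl)c(Nc3c(F)cccc3F)n2)c(OC)cc1N1CCN(C)CC1` gives the highest number of the three measured in a functional assay on NCI-H3122 cells (Homo sapiens) for inhibition, read by CellTiter-Glo, with a stated time of 72 h (on this read-out higher numbers stand for weaker inhibition of growth and lower numbers for stronger inhibition of growth), at 2900 nM; compound 2 `C=CC(=O)Nc1cc(Nc2ncc(Cl)c(Nc3cccc(C(F)(F)F)c3)n2)c(OC)cc1N1CCN(C)CC1` gives 770 nM and compound 1 `C=CC(=O)Nc1cc(Nc2ncc(C)c(Nc3ccccc3S(=O)(=O)C(C)C)n2)c(OC)cc1N1CCN(CC)CC1` gives 2 nM. Compound 4 `C=CC(=O)Nc1cc(Nc2ncc(Cl)c(NC3CC3)n2)c(OC)cc1N1CCN(C)CC1` differs from compound 3 by cyclopropyl in place of 2,6-difluorophenyl on a nitrogen on an aromatic ring. Among the compounds with values here, no measured step swaps an aryl for a non-aromatic ring at this nitrogen; the only step touching this position, a 3.8-fold higher number from compound 2 to compound 3 (0.58 log units; beyond the scatter), was modest. Within the data shown here, with that single step as the only guide, the shift is expected to be small or lost in the scatter, if anything towards a higher number, giving a 1.7-fold higher number from compound 3 to compound 4 (0.24 log units; within the scatter). Compound 4 is estimated at 5000 nM, within 1200 nM to 20000 nM.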

Compound 4, concentration for 50% growth inhibition: 3200 nM
The estimate for compound 4 lay 1.6-fold (0.19 log units) above the measured number; the measured number falls inside the stated range.
By their numbers in this assay, from the lowest: compound 1; then compound 2; then compounds 3 and 4 (each within the scatter of the next).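

In this assay, within the data shown here, an aromatic ring on this nitrogen proves dispensable when it is 2,6-difluorophenyl: the much smaller, non-aromatic cyclopropyl gives a 1.1-fold higher number from compound 3 to compound 4 (0.04 log units; within the scatter) and is the first non-aryl group at this position. The same group does not match 3-(trifluoromethyl)phenyl, with a 4.2-fold higher number from compound 2 to compound 4 (0.62 log units; beyond the scatter) as the result. Nothing available accounts for either step.

From the compounds shown here alone, whether a larger saturated ring such as cyclohexyl or an open chain such as isopropyl on this nitrogen would behave like cyclopropyl remains open. Among these compounds, no compound here differs from compound 1 in only one place, so its far lower number cannot be tied to any single part.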